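The compounds below may be only part of what the source reports. "The series", "measured", "known", "first", "only" and "open" are said of these compounds alone.

In an ADME assay on cells (Hepatocyte, Homo sapiens) for pharmacokinetics, read by LC-MS, with a stated time of 90 min, tested at 1 uM (a lower number here means slower removal, a higher number faster removal of the compound), three compounds have been measured so far:

Compound 1 `COc1ccc(Nc2c(NCCCCCC(=O)NO)c(=O)c2=O)cc1` gives < 4.7 uL/min, which is a limit of the assay rather than a number.
Compound 2 `O=C(CCCCCNc1c(Nc2ccc(C(F)(F)F)cc2)c(=O)c1=O)NO` gives 11 uL/min.
Compound 3 `CC(C)(CCCCC(=O)NO)Nc1c(Nc2ccc(C(F)(F)F)cc2)c(=O)c1=O` gives 29 uL/min.

One change has been made and measured once. Going from compound 2 to compound 1 the change is methoxy in place of trifluoromethyl on an aromatic carbon, and it produced an at least 2.3-fold lower number from compound 2 to compound 1 (0.36 log units; beyond the scatter). Because compound 1 sits at the limit of < 4.7 uL/min in this assay, at which 1 of the 3 values shown sits, the true step may be larger than the shown figure. Of the two plain numbers, compound 3 has the higher one, and compound 2 is lower; how the two cores differ is not broken down here.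

Compound 4 `COc1ccc(Nc2c(NC(C)(C)CCCCC(=O)NO)c(=O)c2=O)cc1` is not yet measured. It differs from compound 3 by methoxy in place of trifluoromethyl on an aromatic carbon, the same change that took compound 2 to compound 1. The expected step from compound 3 to compound 4 is therefore a 2.9-fold lower number from compound 3 to compound 4 (0.46 log units; beyond the scatter), resting on an at least 2.3-fold lower number from compound 2 to compound 1 (0.36 log units; beyond the scatter). Compound 4 is estimated at 10 uL/min, most likely between 4 uL/min and 25 uL/min in this assay.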

Compound 4, intrinsic clearance in a liver preparation (reported as CLH), per the amount of preparation that the assay uses: 9.2 uL/min
For compound 4 the middle estimate is 1.1-fold (0.04 log units) above the measured one; measured number inside the range.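

In this assay, putting methoxy in place of trifluoromethyl on the aromatic carbon of the second core gives a 3.2-fold lower number from compound 3 to compound 4 (0.50 log units; beyond the scatter), so on both cores shown the change goes with slower removal. This shows that the direction of the step carried over from one core to the other, but two cores are too few to make it a rule for the whole series, and the sizes of the two steps cannot be firmly compared: the same change on two cores in this assay, an at least 2.3-fold lower number (0.36 log units; beyond the scatter) from compound 2 to compound 1 and a 3.2-fold lower number (0.50 log units; beyond the scatter) from compound 3 to compound 4; the limit leaves it open whether they differ. Compound 1 gives < 4.7 uL/min, which is a limit of the assay and not a number.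

The compounds shown leave open whether the same step would appear on a core with a longer or shorter chain, or on one carrying an amine. They also leave open how another group on the same aromatic carbon, such as a nitrile or a chlorine atom, would compare with methoxy and trifluoromethyl.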